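The source may report more compounds than this note shows. Statements on the series, on what has been measured and on what is new or still open speak of the compounds shown alone.

Compound 1 `O=S(=O)(c1cccc(C(F)(F)F)c1)N1CCc2ccc(-c3cc(F)cc(OC(F)F)c3)cc21`: 0.19 h
Compound 2 `O=C(O)CCC1Cc2ccc(-c3cc(F)cc(OC(F)F)c3)cc2N1S(=O)(=O)c1cccc(C(F)(F)F)c1`: 1.02 h
Compound 3 `O=C(O)C1CCN(C(=O)CC2Cc3ccc(-c4cc(F)cc(OC(F)F)c4)cc3N2S(=O)(=O)c2cccc(C(F)(F)F)c2)CC1`: 0.502 h

These values come from an ADME assay on microsomes from liver (Mus musculus) for metabolic stability, read by LC-MS, using NADPH, with a stated time of 60 min, tested at 1 uM; a lower number here means that the compound disappears faster, a higher number that the compound lasts longer. Compound 3 stands second of the three, below compound 2 and above compound 1. Compound 4 `O=C(CC1Cc2ccc(-c3cc(F)cc(OC(F)F)c3)cc2N1S(=O)(=O)c1cccc(C(F)(F)F)c1)N1CCS(=O)(=O)CC1` differs from compound 3 in one place, on a carbonyl carbon: 1,1-dioxothiomorpholin-4-yl in place of 4-carboxypiperidin-1-yl on a carbonyl carbon. Among the measured compounds shown here, no measured compound carries 1,1-dioxothiomorpholin-4-yl, so the evidence is indirect. The closest step is a 2.0-fold lower number from compound 2 to compound 3 (0.31 log units; beyond the scatter), and it is modest, as are a 5.4-fold higher number from compound 1 to compound 2 (0.73 log units; beyond the scatter) and a 2.6-fold higher number from compound 1 to compound 3 (0.42 log units; beyond the scatter). Given these modest steps, no change beyond the scatter is expected. The expected change is a 1.3-fold lower number from compound 3 to compound 4 (0.10 log units; within the scatter). For compound 4 the estimated half-life is 0.4 h, with an expected range of 0.15 h to 1 h.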

Compound 4, half-life: 0.0333 h
Estimate against measurement, compound 4: 12-fold (1.08 log units) above; measured number below the stated range.
By their numbers in this assay, from the lowest: compound 4; then compound 1; then compound 3; then compound 2.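

In this assay the group on this carbonyl carbon proves decisive: 1,1-dioxothiomorpholin-4-yl in place of 4-carboxypiperidin-1-yl brings a 15-fold lower number from compound 3 to compound 4 (1.18 log units; beyond the scatter) and gives the shortest half-life of the four. The same group also brings a 31-fold lower number from compound 2 to compound 4 (1.49 log units; beyond the scatter) when the carboxymethyl end is replaced. With hydrogen as the reference, there is a 5.7-fold lower number from compound 1 to compound 4 (0.76 log units; beyond the scatter) where the two carboxylic acids had gained, so the added chain alone does not lengthen the half-life.

A piperidin-1-yl amide without the carboxylic acid would separate the role of the acid from that of the ring. Nothing shown accounts for the drop.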